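The compounds below may be only part of what the source reports. "The series", "measured", "known", "first", "only" and "open" are said of these compounds alone.

Compound 2 `Clc1ccc(CN(Cc2cccnc2)Cc2ncc[nH]2)cc1` sits only at a limit in an assay on isolated protein for agonist activity at nuclear receptor subfamily 1 group D member 1 (Homo sapiens), read by FRET, with a stated time of 1 h (a lower number here means that less compound is needed, a higher number that more compound is needed for the effect), giving > 50000 nM. Compound 1 `Clc1ccc(CN(Cc2cccnc2)Cc2nccs2)cc1` likewise reaches only the limit in this assay, at > 50000 nM. For the measured compounds named here, the one step that connects them, a step that the two limits leave unreadable from compound 1 to compound 2, cannot be read as a size, since both ends rest on (the limit of > 50000 nM in this assay, at which 2 of the 3 values shown sit). Going by the values given here, compound 3 `COc1cccc(CN(Cc2cccnc2)Cc2ccc([N+](=O)[O-])s2)c1`, with its own core, is the only compound with a number in this assay, where compound 3 gives 400 nM. Compound 4 `Cc1sc(CN(Cc2ccc(Cl)cc2)Cc2cccnc2)cc1Br` differs from compound 2 by 4-bromo-5-methylthiophen-2-yl in place of 1H-imidazol-2-yl on a saturated chain carbon bound to an amine nitrogen. No measured step bears directly on this change: the only step shown is unreadable, and the value of compound 3 belongs to a different core and a different thiophene substitution, so no step to it is given. Compound 2 is therefore expected to move with an at least 8.3-fold lower number from compound 2 to compound 4 (0.92 log units; beyond the scatter) in this assay, with wide uncertainty. Compound 4 is estimated at 6000 nM in this assay, in a range from 600 nM to 50000 nM.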

Compound 4, half-maximal effective concentration: 250 nM
Estimate against measurement, compound 4: 24-fold (1.38 log units) above; the measured number lies below the stated range.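

For the compounds shown here, on a saturated chain carbon bound to an amine nitrogen, 4-bromo-5-methylthiophen-2-yl gives the first readable steps on this core in this assay: an at least 200-fold lower number from compound 2 to compound 4 (2.30 log units; beyond the scatter), and an at least 200-fold lower number from compound 1 to compound 4 (2.30 log units; beyond the scatter). The core shared by compound 1, compound 2 and compound 4 can therefore reach a measured number in this assay, as compound 4 does at 250 nM, which the two earlier compounds on this core could not show. Each step gives only a minimum size, as its starting point is a limit and not a number: the limit of > 50000 nM in this assay, at which 2 of the 4 values shown sit.

The compounds shown leave open whether the step goes with the thiophene ring, the bromine or the methyl, since all three enter together. A plain thiophen-2-yl or a 5-methylthiophen-2-yl at this place would separate these parts, and how 1H-imidazol-2-yl and 1,3-thiazol-2-yl rank against each other remains unreadable.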